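Ethyl in Place of Hydrogen on a Pyrazole Carbon

The source may hold more compounds than are shown below. What is called first, only, known or untested is meant among the compounds shown, and "the series" means these compounds.

The series rests on one shared core carrying a pyridin-2-yl group and an aryl-linked carboxylic acid chain. Compound 1 `Cc1nn(-c2ccccn2)c2cc(-c3ccc(CCCC(=O)O)cc3)ccc12` gives 117% in a functional assay on cells for agonist activity at Free fatty acid receptor 1 (Mus musculus), read by FLIPR and calcium flux, with a stated time of 5 min; on this read-out lower numbers stand for smaller maximal responses and higher numbers for larger maximal responses. Compound 2 `Cc1nn(-c2ccccn2)c2cc(-c3ccc(CCC(=O)O)cc3Cl)ccc12` gives 102% in this assay. Compound 3 `O=C(O)CCc1ccc(-c2ccc3cnn(-c4ccccn4)c3c2)cc1` gives 106% in this assay, the second highest of the three numbers: its gap to compound 2 lies within the scatter, while compound 1 stands beyond the scatter above it. Compounds 1 and 2 each differ from compound 3 in more than one place. Among the measured compounds shown here, no single-change step is known among the measured compounds.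

Compound 4 `CCc1nn(-c2ccccn2)c2cc(-c3ccc(CCC(=O)O)cc3)ccc12` differs from compound 3 by ethyl in place of hydrogen on an aromatic carbon in a single place. All three measured compounds reach a full response regardless of their other differences, so no change beyond the scatter is expected in this assay for the step of a number 1 percentage points lower from compound 3 to compound 4 (within the scatter). Compound 4 is therefore estimated to give 105% in this assay, with a range from 92% to 118%.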

Compound 4, largest response reached (reported as efficacy), in percent of the reference or control that the assay uses: 93%
The estimate for compound 4 lay 12 percentage points above the measured number; the range from low to high includes it.
By their numbers in this assay, from the lowest: compounds 4, 2 and 3 (each within the scatter of the next, the first and the last beyond it); then compound 1.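

Ethyl in place of hydrogen on this aromatic carbon, next to the ring nitrogen, gives a number 13 percentage points lower from compound 3 to compound 4 (beyond the scatter) in this assay, the first single-change step in the series. The earlier compounds shown here, which differ from one another in more than one place, could not show that the largest response depends on the group at this position; this step shows that it does, although only modestly. No measurement shown gives a reason for this step.

The compounds shown leave open how the response changes with other groups on this carbon, such as a propyl chain, a methoxy group or an amine. They also leave open whether ethyl would lower the response by a similar amount on a compound with a different acid chain.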